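Swapping Fluoro for Bromo on an Antiproliferative Compound

This account rests on a few compounds, and the source may have more. Where it says the series, first, only, none or still open, it means among the compounds named here.

Compound 1 `COc1cccc(Nc2nccc(-c3ccc(F)cc3)n2)c1` is the starting point. Within the data shown here, in a functional assay on MCF7 cells (Homo sapiens) for antiproliferative activity, read by MTT assay (a higher number here means a weaker inhibitor, a lower number a stronger inhibitor), compound 1 gives 412000 nM which is the higher of the two numbers measured so far and thus the weaker result. Compound 2 `COc1cccc(Nc2nccc(-c3ccc(Cl)c(Cl)c3)n2)c1` differs from compound 1 in its halogens, and in this assay compound 2 gives 21000 nM which is lower by more than the usual scatter. Compound 3 `COc1cccc(Nc2nccc(-c3ccc(Br)cc3)n2)c1` has not yet been measured. It keeps the core of compound 1 and makes one change: bromo in place of fluoro on an aromatic carbon. Among the measured compounds shown here, two measured compounds are thin evidence, and this exact swap has no measured precedent. Still, compound 2 at 21000 nM shows that different halogens can go with a lower number. A downward step beyond the scatter is therefore expected, and the estimated change is a 5.2-fold lower number from compound 1 to compound 3 (0.71 log units; beyond the scatter). For compound 3 the expected value is 80000 nM with an estimated range from 25000 nM to 300000 nM.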

Compound 3, half-maximal inhibitory concentration: 278000 nM
Estimate against measurement, compound 3: 3.5-fold (0.54 log units) below; the range from low to high includes it.
By their numbers in this assay, from the lowest: compound 2; then compounds 3 and 1 (each within the scatter of the next).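

In this assay, changing 4-fluorophenyl to 4-bromophenyl gives a 1.5-fold lower number from compound 1 to compound 3 (0.17 log units; within the scatter) and so leaves the two compounds indistinguishable. Among these compounds, this is the first comparison here that isolates a single place on the ring: with only this swap separating them, fluoro and bromo cannot be told apart at this position, whereas compound 1 and compound 2 differ in more than one place and could not show this. Nothing measured here offers an explanation for this result.

As far as these compounds go, whether a single chloro at this same place would also fall within the scatter of compound 1 remains open. So does the question of whether a group other than a halogen, such as an amine or a carboxylic acid, would shift the number beyond the scatter.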